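A Remote Cyano Group and the Expected Acid Dissociation

The compounds below may be only part of what the source reports. "The series", "measured", "known", "first", "only" and "open" are said of these compounds alone.

Measured compounds:
compound 1 `COc1ccc(F)cc1CNCCCNc1ccnc2cc(Cc3cc(C)cc(C)c3)ccc12` gives 9.47 in a physicochemical assay for acid dissociation;
compound 2 `Fc1ccc(-c2ccc3c(NCCCNCc4ccco4)ccnc3c2)cc1` gives 9.47;
compound 3 `COc1cccc(CNCCCNc2ccnc3cc(Cc4ccccc4)ccc23)c1O` gives 9.47.

The three compounds share a common core and differ only in the groups carried on their aromatic rings. Despite those differences, compound 3 stands level with compounds 1 and 2 at the digits shown: its nearest neighbour is compound 1, with no change at the digits shown, and its furthest is compound 2, again with no change at the digits shown. All of this lies within the usual scatter of this assay, so none of the three can be called higher or lower than another.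

Compound 4 `COc1cccc(CNCCCNc2ccnc3cc(Cc4ccc(C#N)cc4)ccc23)c1O` has not yet been measured. It differs from compound 3 in a single place: cyano in place of hydrogen on an aromatic carbon. The cyano group enters on a six-membered aromatic ring of carbon only, para to a large group, so the substitution sits on one aromatic ring while the rest of the molecule is untouched.

Since changes on the aromatic rings between compounds 1, 2 and 3 left the measured values unchanged at the digits shown, compound 4 is expected to follow suit, with a step from compound 3 that is no larger than the scatter, a number 0.07 log units lower from compound 3 to compound 4 (within the scatter). For compound 4 the estimated value in this assay is 9.4, expected to fall between 9.05 and 9.7.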

Compound 4, acid dissociation constant: 9.47
Estimate against measurement, compound 4: 0.07 log units below; measured number inside the range.
By their numbers in this assay, from the lowest: compounds 1, 2, 3 and 4 (each within the scatter of the next).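

Among the compounds shown here, compound 3 and compound 4 are the first pair here that differ in only one place, so this is the first time a single change can be read on its own in this assay. Placing cyano on an aromatic carbon, para to a large group, which turns the benzyl into 4-cyanobenzyl, gives a clean result (no change at the digits printed from compound 3 to compound 4 (within the scatter)). The earlier compounds differ in several places at once and could only show that their values sit level, whereas this pair shows that this one change at this one position leaves the reading within the scatter, and nothing available explains why.

On these data alone, this single step speaks for cyano at this position only, so it remains open whether a carboxylic acid or a dimethylamino group on the same aromatic carbon would also leave the reading within the scatter. Also open, as far as these compounds go, is whether a longer chain in place of the benzyl link, or cyano on another aromatic carbon of the molecule, would give the same result.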